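A few compounds are considered here, and "the series" means these few. Any claim that something is new, unique, unknown or untested is made for them only; others in the source may bear on it.

Measured so far:
- compound 1, `Cc1cc(C(F)(F)F)cc(NC[C@@H]2CC3(CC3)CN2C(=O)c2nc(C)sc2-c2ccccc2)n1`, gives 7.8 in a functional assay on CHO cells for antagonist activity at Orexin/Hypocretin receptor type 1 (Homo sapiens), read by FLIPR and calcium flux; on this read-out lower numbers stand for lower potency and higher numbers for higher potency (the scale is a negative logarithm)
- compound 2, `Cc1nc(C(=O)N2CC3(CC3)C[C@H]2CNc2cc(C(F)(F)F)ccn2)c(-c2ccccc2)s1`, gives 8.2 in this assay

Compound 2 stands highest of the two numbers; the nearest, compound 1, lies lower by a number 0.40 log units higher from compound 1 to compound 2 (beyond the scatter), which is more than the usual scatter. That single step, hydrogen in place of methyl on an aromatic carbon, is the only measured change shown, and it concerns the same ring that is now exchanged.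

Compound 3, `Cc1ccnc(NC[C@@H]2CC3(CC3)CN2C(=O)c2nc(C)sc2-c2ccccc2)n1`, carries 4-methylpyrimidin-2-yl in place of 4-(trifluoromethyl)pyridin-2-yl on an amine nitrogen. For the measured compounds named here, this swaps both the ring itself and the group attached to it, so no measured step matches it directly. Going by the values given here, the step from compound 1 to compound 2 shows only that the ring substitution pattern matters at the modest level, and a full ring exchange is a larger change with no direct precedent here. In this assay compound 3 is expected to fall by a number 0.60 log units lower from compound 2 to compound 3 (beyond the scatter) relative to compound 2, with wide uncertainty. The estimate for compound 3 is 7.6, with a range from 6.8 to 8.4.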

Compound 3, negative logarithm of the antagonist equilibrium constant: 6.1
The estimate for compound 3 lay 1.50 log units above the measured number; the measured number lies below the stated range.
By their numbers in this assay, from the lowest: compound 3; then compound 1; then compound 2.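

At this place on the amine nitrogen, the choice of aromatic group matters far more than the earlier pair could show: in this assay the exchange of 4-(trifluoromethyl)pyridin-2-yl for 4-methylpyrimidin-2-yl gives a number 2.10 log units lower from compound 2 to compound 3 (beyond the scatter) and so stands well apart from the modest a number 0.40 log units higher from compound 1 to compound 2 (beyond the scatter) within the same series. Starting instead from 6-methyl-4-(trifluoromethyl)pyridin-2-yl gives a number 1.70 log units lower from compound 1 to compound 3 (beyond the scatter) so the large drop appears from both trifluoromethyl-bearing compounds, whichever serves as the reference. Nothing among the data shown explains why the number falls this far.

The exchange alters the ring and its substituent at once, so the contribution of the second ring nitrogen cannot be told apart from that of methyl replacing trifluoromethyl. A 4-methylpyridin-2-yl group or a 4-(trifluoromethyl)pyrimidin-2-yl group on the same amine nitrogen would each change only one of these two features, and would show which of them carries the drop.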